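Allyl on the sulfur of compound 2

This account rests on a few compounds, and the source may have more. Where it says the series, first, only, none or still open, it means among the compounds named here.

Measured in a functional assay on HT cells (Homo sapiens) for antiproliferative activity, read by fluorescence, with a stated time of 72 h; a higher number here means a weaker inhibitor of growth, a lower number a stronger inhibitor of growth:
Compound 1 `CC(C)c1n[nH]c2c(NCc3ccc(-c4ccccn4)cc3)nc(SCC(O)CN)nc12`: 55 nM
Compound 2 `CC(C)c1n[nH]c2c(NCc3ccc(-c4ccccn4)cc3)nc(S)nc12`: 2760 nM

Compound 2, at 2760 nM, has the higher of the two numbers, so it is the weaker growth inhibitor. Compound 3 `C=CCSc1nc(NCc2ccc(-c3ccccn3)cc2)c2[nH]nc(C(C)C)c2n1` differs from it in one place: allyl in place of hydrogen on a sulfur. Within the data shown here, one measured step bears on this change, the large 50-fold higher number from compound 1 to compound 2 (1.70 log units; beyond the scatter), where hydrogen replaces 3-amino-2-hydroxypropyl on a sulfur. Allyl is a different group from that chain, so only part of this step is expected to return, toward a lower number. The expected change in this assay is a 9.2-fold lower number from compound 2 to compound 3 (0.96 log units; beyond the scatter). For compound 3 the estimated value is 300 nM, with an expected range of 70 nM to 1300 nM.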

Compound 3, concentration for 50% growth inhibition: 1010 nM
Compound 3: middle estimate off by 3.4-fold (0.53 log units), on the low side; measured number inside the range.
By their numbers in this assay, from the lowest: compound 1; then compound 3; then compound 2.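

Putting allyl on the sulfur gives only part of the gain seen with the longer chain in this assay: there is a 2.7-fold lower number from compound 2 to compound 3 (0.44 log units; beyond the scatter), yet also an 18-fold higher number from compound 1 to compound 3 (1.26 log units; beyond the scatter). So a carbon group on this sulfur is not enough on its own to reach the number of compound 1, and most of that gain goes with the 3-amino-2-hydroxypropyl chain itself. Nothing available explains this difference.

From the compounds shown here alone, it remains open whether the amine or the hydroxyl of that chain matters more. A 3-aminopropyl or a 2-hydroxypropyl group on the sulfur would separate the two.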